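From 4-methoxyphenyl to 3-nitrophenyl at one ring carbon

This account rests on a few compounds, and the source may have more. Where it says the series, first, only, none or still open, it means among the compounds named here.

Measured so far in an ADME assay on Vero cells (Chlorocebus sabaeus) for cytotoxicity, read by sulforhodamine B assay, with a stated time of 3 days; a higher number here means that more compound is tolerated, a lower number that less compound is tolerated:
compound 1 `COc1ccc(C2C(C(=O)Nc3ccc(Cl)cc3)=C(C)NC(C)=C2C(=O)Nc2ccc(Cl)cc2)cc1` gives 20 ug/mL here
compound 2 `CC1=C(C(=O)Nc2ccc(Cl)cc2)C(c2ccco2)C(C(=O)Nc2ccc(Cl)cc2)=C(C)N1` gives 24 ug/mL here
compound 3 `CC1=C(C(=O)Nc2ccc(Cl)cc2)C(c2ccncc2)C(C(=O)Nc2ccc(Cl)cc2)=C(C)N1` gives 78 ug/mL here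

Compound 1 stands at the low end of these three numbers, although the nearest value is no real distance away (a 1.2-fold higher number from compound 1 to compound 2 (0.08 log units; within the scatter)). The furthest value is clearly separate (a 3.9-fold higher number from compound 1 to compound 3 (0.59 log units; beyond the scatter)). The unmeasured compound 4 `CC1=C(C(=O)Nc2ccc(Cl)cc2)C(c2cccc([N+](=O)[O-])c2)C(C(=O)Nc2ccc(Cl)cc2)=C(C)N1` keeps the core of compound 1 and alters one group (3-nitrophenyl in place of 4-methoxyphenyl on a saturated ring carbon), with 3-nitrophenyl in place of 4-methoxyphenyl on a saturated ring carbon.

For the measured compounds named here, the measured steps at this same ring carbon are the only guide. Furan-2-yl made no difference beyond the scatter, while pyridin-4-yl gave the only modest rise (a 3.3-fold higher number from compound 2 to compound 3 (0.51 log units; beyond the scatter)). Going by the values given here, no compound with a nitro group has been measured, so the guide is loose. The 3-nitrophenyl group keeps a six-membered aromatic ring of carbon only, so a step within the scatter, slightly upward if anything, is expected in this assay. The expected step is a 1.3-fold higher number from compound 1 to compound 4 (0.11 log units; within the scatter) in size. For compound 4 the estimated value is 26 ug/mL with an expected range from 12 ug/mL to 60 ug/mL at the upper end.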

Compound 4, half-maximal cytotoxic concentration: 26 ug/mL
The estimate for compound 4 equals the measured number at the digits printed; the measured number falls inside the stated range.
By their numbers in this assay, from the lowest: compounds 1, 2 and 4 (each within the scatter of the next); then compound 3.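

In this assay, the first nitro-substituted ring at this saturated ring carbon stays level with 4-methoxyphenyl (a 1.3-fold higher number from compound 1 to compound 4 (0.11 log units; within the scatter)) and with furan-2-yl (a 1.1-fold higher number from compound 2 to compound 4 (0.03 log units; within the scatter)). Against pyridin-4-yl the same group gives a clear gap (a 3.0-fold lower number from compound 3 to compound 4 (0.48 log units; beyond the scatter)), so compound 3 alone stands apart among the four, while compounds 1, 2 and 4 cannot be told apart despite their different groups. Nothing available here explains why compound 3 is separate from the other three.

As far as these compounds go, it remains open whether pyridin-3-yl or plain phenyl at this ring carbon would group with compound 3 or with the other three. The same question holds for a phenyl ring carrying an amine or a carboxylic acid, and for the nitro group moved to give 4-nitrophenyl.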